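From bromo to nitro on an aromatic carbon

The compounds below may be only part of what the source reports. "The series", "measured", "known", "first", "only" and "open" are said of these compounds alone.

Compound 1 `Cc1cnc(Nc2ccc(C#N)cc2)nc1OCC(=O)Nc1ccc(Cl)cc1` gives > 317000 nM as a limit of the assay
Compound 2 `Cc1cnc(Nc2ccc(C#N)cc2)nc1OCC(=O)Nc1ccccc1Cl` gives 197000 nM as a number
Compound 3 `Cc1cnc(Nc2ccc(C#N)cc2)nc1OCC(=O)Nc1ccc(Br)cc1` gives 34700 nM as a number

All three were tested in an ADME assay on MT4 cells (Homo sapiens) for cytotoxicity, read by MTT assay, with a stated time of 5 days (a higher number here means that more compound is tolerated, a lower number that less compound is tolerated), and compound 3 holds the lower of the two true numbers. Its nearest neighbour is compound 2 with the step being a 5.7-fold lower number from compound 2 to compound 3 (0.75 log units; beyond the scatter) in size. For the measured compounds named here, compound 4 `Cc1cnc(Nc2ccc(C#N)cc2)nc1OCC(=O)Nc1ccc([N+](=O)[O-])cc1` is still unmeasured and carries nitro in place of bromo on an aromatic carbon as its only change. The step with a swap at this same place is an at least 9.1-fold lower number from compound 1 to compound 3 (0.96 log units; beyond the scatter) and it suggests that this group can move the number by a modest amount or more. Since compound 3 sits lowest, a modest rise in this assay is expected, estimated as a 2.0-fold higher number from compound 3 to compound 4 (0.30 log units; within the scatter) for this swap. For compound 4 the estimated value is 70000 nM with an expected range from 15000 nM to 280000 nM in this measurement.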

Compound 4, half-maximal cytotoxic concentration: 66300 nM
The estimate for compound 4 lay 1.1-fold (0.02 log units) above the measured number; the range from low to high includes it.
By their numbers in this assay, from the lowest: compounds 3 and 4 (each within the scatter of the next); then compound 2. At a limit, above all of these: compound 1.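

In this assay, nitro and bromo cannot be told apart at this position, a 1.9-fold higher number from compound 3 to compound 4 (0.28 log units; within the scatter), although nitro brings three heavy atoms where bromo has one. The swap from 2-chlorophenyl to 4-nitrophenyl still registers, a 3.0-fold lower number from compound 2 to compound 4 (0.47 log units; beyond the scatter). Chloro at this position stands apart from nitro, an at least 4.7-fold lower number from compound 1 to compound 4 (0.67 log units; beyond the scatter), but this step is only a floor, as compound 1 gives a limit: the limit of > 317000 nM in this assay, at which 1 of the 4 values shown sits.

As far as these compounds go, it remains open how far compound 1 truly lies from the others, and whether an amine or a carboxylic acid here would track nitro and bromo or chloro.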